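A few compounds are considered here, and "the series" means these few. Any claim that something is new, unique, unknown or untested is made for them only; others in the source may bear on it.

Two compounds have been measured in a physicochemical assay for solubility, with a stated time of 18 h, at pH 7.4; on this read-out higher numbers stand for higher solubility and lower numbers for lower solubility:

compound 1, `COc1cccc(CNCCCNc2ccnc3cc(Oc4ccc(Cl)cc4)ccc23)c1O`, gives 14500 nM
compound 2, `Fc1ccc(-c2ccc3c(NCCCNCc4ccco4)ccnc3c2)cc1`, gives 32000 nM

Among these two numbers compound 1 stands at the lower end; the number for compound 2 lies above it by a margin beyond the usual scatter of this assay. Among the measured compounds shown here, no pair of these measured compounds differs in only one place, so no single structural step can yet be read off against a measured change in solubility.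

Compound 3, `COc1cccc(CNCCCNc2ccnc3cc(Cc4cccc(C(F)(F)F)c4)ccc23)c1O`, has not been measured. It differs from compound 1 in one place: 3-(trifluoromethyl)benzyl in place of 4-chlorophenoxy on an aromatic carbon. The outgoing group carries one hydrogen-bond acceptor and the incoming group carries none, as counted in that comparison, and the incoming group is the larger of the two by heavy atoms.

For the measured compounds named here, with no measured step of this kind to lean on, the expectation for this change is a moderate drop in solubility, beyond the scatter but not large: the step from compound 1 to compound 3 is estimated at a 2.4-fold lower number from compound 1 to compound 3 (0.38 log units; beyond the scatter). On that basis compound 3 is expected to give about 6000 nM in this assay, with a plausible range from 2000 nM to 18000 nM.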

Compound 3, solubility: 4200 nM
Compound 3: middle estimate off by 1.4-fold (0.15 log units), on the high side, within the range that was stated.
By their numbers in this assay, from the lowest: compound 3; then compound 1; then compound 2.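

Among the compounds shown here, this is the first comparison here between compounds that differ in only one place. In this assay, putting 3-(trifluoromethyl)benzyl in place of 4-chlorophenoxy on this aromatic carbon gives a 3.5-fold lower number from compound 1 to compound 3 (0.54 log units; beyond the scatter) and so shows that the read-out responds to a change at this position, with the shared core left untouched. Several differences come bundled in this single change, since the incoming group is larger by heavy atoms, carries fluorine rather than chlorine, and lacks the hydrogen-bond acceptor counted in the outgoing group, and no information here separates these differences or says which of them, if any, accounts for the step.

Going by these compounds, one step gives a single comparison at this position, not a trend, so what a morpholine or a carboxylic acid on the same aromatic carbon would do to the number remains open. On these data alone, it is also open whether the same replacement would give a step of similar size on a compound with another group in place of the substituted benzylamine side of the chain, such as a furan-2-ylmethyl group.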